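The source may report more compounds than this note shows. Statements on the series, on what has been measured and on what is new or still open speak of the compounds shown alone.

Working notes on the series, measured in a functional assay on B16-F10 cells (Mus musculus) for cytotoxicity, read by MTT assay, with a stated time of 72 h; on this read-out lower numbers stand for stronger inhibition and higher numbers for weaker inhibition:

- compound 1 `COc1ccc2[nH]c(-c3ccc[nH]3)c(C3CC(=O)NC3=O)c2c1`: 600 nM
- compound 2 `O=C1CC(c2c(-c3ccc[nH]3)[nH]c3ccccc23)C(=O)N1`: 2000 nM

Among the measured compounds shown here, compound 2 has the higher of the two numbers in this assay, so it is the weaker of the pair, with compound 1 as its only neighbour. The next analogue is compound 3 `Cc1ccc2[nH]c(-c3ccc[nH]3)c(C3CC(=O)NC3=O)c2c1`, which differs from compound 2 by methyl in place of hydrogen on an aromatic carbon.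

For the measured compounds named here, only one measured step bears on this change, a modest one with hydrogen in place of methoxy on an aromatic carbon: a 3.3-fold higher number from compound 1 to compound 2 (0.52 log units; beyond the scatter). Read backwards, it links a group in place of that hydrogen with a lower number. However, methoxy is not methyl, and no methyl compound has been measured, so this single pair is a loose guide. A shift in the same direction is expected for methyl, smaller than the one seen for methoxy and possibly lost in the scatter.

The expected step is a 1.8-fold lower number from compound 2 to compound 3 (0.26 log units; within the scatter).

Compound 3 is estimated at 1100 nM, with an expected range of 450 nM to 2600 nM.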

Compound 3, half-maximal inhibitory concentration: 500 nM
Compound 3: the middle estimate sits 2.2-fold (0.34 log units) above what was measured, within the range that was stated.
By their numbers in this assay, from the lowest: compounds 3 and 1 (each within the scatter of the next); then compound 2.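

In this assay the methyl group on this aromatic carbon of the six-membered ring moves the number beyond the scatter (a 4.0-fold lower number from compound 2 to compound 3 (0.60 log units; beyond the scatter)), so the lower number seen earlier with methoxy is not confined to a group containing oxygen. A single carbon is enough at this position to separate a substituted compound from the unsubstituted compound 2, at least for these two groups. Exchanging methoxy for methyl leaves the value within the scatter (a 1.2-fold lower number from compound 1 to compound 3 (0.08 log units; within the scatter)), so this assay does not separate the two groups, and no measurement in hand accounts for either step.

Still open, as far as these compounds go, is whether the same shift from hydrogen holds for fluorine, chlorine, an amine, a carboxylic acid or a longer chain such as propyl on this aromatic carbon, and whether any of these would separate from the level shared by compound 1 and compound 3. With only hydrogen, methyl and methoxy shown at one position, the series also leaves open how the same groups behave elsewhere on the shared core.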